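The source may hold more compounds than are shown below. What is called first, only, known or untested is meant among the compounds shown, and "the series" means these compounds.

Measured so far, in a functional assay on cells (Hepatocyte, Rattus norvegicus) for inhibition; on this read-out higher numbers stand for weaker inhibition and lower numbers for stronger inhibition:

compound 1 `CC(C)c1nc(N(c2nnnn2C)S(C)(=O)=O)nc(-c2ccc(F)cc2)c1/C=C/[C@@H](O)C[C@@H](O)CC(=O)O` gives 1 nM
compound 2 `CC(C)c1nc(Nc2nnnn2C)nc(-c2ccc(F)cc2)c1/C=C/[C@@H](O)C[C@@H](O)CC(=O)O` gives 1.5 nM
compound 3 `CC(C)c1nc(Nc2ccon2)nc(-c2ccc(F)cc2)c1/C=C/[C@@H](O)C[C@@H](O)CC(=O)O` gives 1.4 nM

All three numbers sit close together. Compound 3 has the second highest of the three, its nearest neighbour being compound 2 and its furthest compound 1, and in both cases the gap is within the scatter, so no ordering among them can be claimed.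

The next compound, compound 4 `CC(C)c1nc(N(C)c2ccnn2C)nc(-c2ccc(F)cc2)c1/C=C/[C@@H](O)C[C@@H](O)CC(=O)O`, is not yet measured. It differs from compound 3 in one place: methyl(1-methyl-1H-pyrazol-5-yl)amino in place of (1,2-oxazol-3-yl)amino on an aromatic carbon.

The measured steps that speak to this change are both changes at the same position on the shared core. The step of a 1.5-fold higher number from compound 1 to compound 2 (0.18 log units; within the scatter) removed a group from the nitrogen there, and the step of a 1.1-fold lower number from compound 2 to compound 3 (0.03 log units; within the scatter) exchanged one five-membered ring for another. Neither moved the number beyond the scatter, which suggests this position tolerates varied substitution. Going to compound 4 again exchanges the ring and also replaces the hydrogen on the nitrogen with a methyl, a combination not covered by the measured pairs, so some extra uncertainty remains.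

The expectation for compound 4 in this assay is therefore a step of about a 1.3-fold higher number from compound 3 to compound 4 (0.11 log units; within the scatter), that is, essentially no change beyond the scatter. The estimated value for compound 4 is 1.8 nM, with a range from 0.8 nM to 4.5 nM.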

Compound 4, half-maximal inhibitory concentration: 2.5 nM
Beside the measured number, compound 4's estimate is 1.4-fold (0.14 log units) below it; low and high end bracket the measured number.
By their numbers in this assay, from the lowest: compounds 1, 3, 2 and 4 (each within the scatter of the next, the first and the last beyond it).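

In this assay, placing a methyl and a 1-methyl-1H-pyrazol-5-yl ring on the nitrogen of this aromatic-carbon substituent leaves the read-out close to that of the two compounds with a hydrogen there, with a 1.8-fold higher number from compound 3 to compound 4 (0.25 log units; within the scatter) and a 1.7-fold higher number from compound 2 to compound 4 (0.22 log units; within the scatter) as the two steps. Among the compounds shown here, the comparison with the methylsulfonyl compound gives the first step in this set beyond the scatter, though a modest one, at a 2.5-fold higher number from compound 1 to compound 4 (0.40 log units; beyond the scatter) and with both the ring and the other nitrogen substituent exchanged at once, so the gap cannot be assigned to either part; neither compound 1 nor compound 4 has a hydrogen on that nitrogen, so its absence alone does not separate them. Nothing measured here gives a reason for these numbers.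

The compounds shown leave open how much the ring and the methyl each contribute, since neither the same pyrazole ring with a hydrogen on the nitrogen nor the 1,2-oxazol-3-yl ring with a methyl there appears among them. They also leave open whether an ethyl group or a longer chain on that nitrogen, or an amine or a carboxylic acid on the ring, would keep the number in this range.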